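Swapping the amide substituent on a shared dihydropyridine core

The source may hold more compounds than are shown below. What is called first, only, known or untested is meant among the compounds shown, and "the series" means these compounds.

Of the compounds shown here, two built on one shared core have been measured. Compound 1 `CCOC(=O)C1=C(C)NC(C)=C(C(=O)OCC)C1c1ccc(OCC(=O)NCc2ccccc2)cc1` carries a benzyl group on an amide-type nitrogen, and in a functional assay on the whole organism (strain Wistar) for inhibition, with Rattus norvegicus as the target, read by paw edema, with stated times of 30 min and 3 h, at a dose of 20 mg/kg (a lower number here means less inhibition, a higher number more inhibition at the dose given (going by the name of the read-out)), compound 1 gives 31.1%. Compound 2 `CCOC(=O)C1=C(C)NC(C)=C(C(=O)OCC)C1c1ccc(OCC(=O)Nc2nc3ccccc3s2)cc1` carries a 1,3-benzothiazol-2-yl group in the same place, and in this assay compound 2 gives 65.9%. Among the two numbers, compound 2 stands highest, and the single step available is a number 34.8 percentage points higher from compound 1 to compound 2 (beyond the scatter). This shows that the group on the amide-type nitrogen can move the read-out strongly.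

Compound 3 `CCOC(=O)C1=C(C)NC(C)=C(C(=O)OCC)C1c1ccc(OCC(=O)NNC(=O)c2sccc2Cl)cc1` has not been measured. It differs from compound 2 as follows: ((3-chlorothiophen-2-yl)carbonyl)amino in place of 1,3-benzothiazol-2-yl on an amide-type nitrogen. Among the compounds with values here, no measured step covers this kind of exchange, so the direction cannot be read from the data; the only guidance is that the one known step, a number 34.8 percentage points higher from compound 1 to compound 2 (beyond the scatter), was large, so a large step in either direction is possible here too. Taking a cautious middle position, compound 3 is estimated at 45%, with a range from 25% to 68%. The expected step is a number 20.9 percentage points lower from compound 2 to compound 3 (beyond the scatter).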

Compound 3, a percentage reported as inhibition, in the whole organism at one dose (the size of the read-out at that dose, not a potency): 56.3%
The estimate for compound 3 lay 11.3 percentage points below the measured number, and the stated range covers the measured number.
By their numbers in this assay, from the lowest: compound 1; then compounds 3 and 2 (each within the scatter of the next).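

In this assay, two quite different groups on the amide-type nitrogen cannot be told apart: a number 9.6 percentage points lower from compound 2 to compound 3 (within the scatter). The ((3-chlorothiophen-2-yl)carbonyl)amino group has one five-membered aromatic ring, a double bond outside aromatic rings and a hydrogen-bond donor, whereas 1,3-benzothiazol-2-yl has two aromatic rings and no donor, so a high read-out here does not require the benzothiazole group itself, and replacing benzyl with the new group also gives a number 25.2 percentage points higher from compound 1 to compound 3 (beyond the scatter). Nothing available explains why either group differs from benzyl, and the three compounds alone cannot supply a reason.

On these data alone, it remains open which part of the new group matters, for example whether the same group without its chlorine, or with a plain phenyl ring in place of the chlorothiophene, would stay level with compound 2. All three groups shown contain an aromatic ring, so it is also open how an open butyl chain or a simple amine on this nitrogen would behave at this single dose.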